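The compounds below may be only part of what the source reports. "The series", "measured", "known", "first", "only" and "open" are said of these compounds alone.

Compound 1 `C[C@H](NCCC1OCC(C)(C)CO1)C(=O)N[C@H]1[C@@H](OCc2ccccc2)O[C@H](COCc2ccccc2)[C@@H](OCc2ccccc2)[C@@H]1OCc1ccccc1` and compound 2 `CC(C)C[C@H](NCCC1OCC(C)(C)CO1)C(=O)N[C@H]1[C@@H](OCc2ccccc2)O[C@H](COCc2ccccc2)[C@@H](OCc2ccccc2)[C@@H]1OCc1ccccc1` share one core, while compound 3 `CC(=O)OC[C@H]1O[C@H](OC(C)=O)[C@H](NC(=O)[C@H](C)NCCC2OCC(C)(C)CO2)[C@@H](OC(C)=O)[C@@H]1OC(C)=O` and compound 4 `CC(=O)OC[C@H]1O[C@H](OC(C)=O)[C@H](NC(=O)[C@H](CC(C)C)NCCC2OCC(C)(C)CO2)[C@@H](OC(C)=O)[C@@H]1OC(C)=O` share another; the difference between the two cores is not broken down here. In a functional assay on the whole organism (Ear, strain ICR) for inhibition, with Mus musculus as the target, with stated times of 30 min and 2 h, at a dose of 10 umol/kg by the oral route (a lower number here means less inhibition, a higher number more inhibition at the dose given (going by the name of the read-out)), compound 1 gives 90.3% and compound 2 gives 76.7%, so that a number 13.6 percentage points lower from compound 1 to compound 2 (beyond the scatter) follows from isopropyl in place of hydrogen on a saturated chain carbon, two bonds along the chain from an amine nitrogen and a carbonyl carbon. In this assay compound 3 gives 84.2%, which sits within the scatter of both compound 1 and compound 2. Compound 4 carries the same change on its own core, namely (isopropyl in place of hydrogen on a saturated chain carbon, two bonds along the chain from an amine nitrogen and a carbonyl carbon). Because a number 13.6 percentage points lower from compound 1 to compound 2 (beyond the scatter) was modest, compound 4 is expected to show a step of about the same size, a number 13.6 percentage points lower from compound 3 to compound 4 (beyond the scatter). On that basis compound 4 is estimated at 70.6%, with a likely range from 58% to 82%.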

Compound 4, a percentage reported as inhibition, in the whole organism at one dose (the size of the read-out at that dose, not a potency): 86.6%
For compound 4 the middle estimate is 16 percentage points below the measured one; the whole stated range lies below it.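

In this assay, the same change gives a number 2.4 percentage points higher from compound 3 to compound 4 (within the scatter), so it leaves the read-out within the usual scatter on this core. A step measured on the core of compound 1 therefore did not carry over in size to the core of compound 3 in this series: the same change on two cores in this assay, a number 13.6 percentage points lower (beyond the scatter) from compound 1 to compound 2 and a number 2.4 percentage points higher (within the scatter) from compound 3 to compound 4, 16 percentage points apart, beyond the scatter of two such steps This comparison rests on a single pair on each core at one dose, and it does not show which difference between the cores matters or how the change would behave on any other core.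

The compounds shown leave open how a longer chain, an amine or a carboxylic acid on that saturated chain carbon would behave on either core. They also leave open whether a core carrying hydroxyl groups would give a step like either of these two.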